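The compounds below may be only part of what the source reports. "The series", "measured", "known", "first", "only" and "open" are said of these compounds alone.

Measured so far:
compound 1, `Cn1c(=O)c2c(nc(CCSc3cccc(Br)c3)n2C)n(C)c1=O`: 372000 nM
compound 2, `Cn1c(=O)c2c(nc(COc3cccc(Br)c3)n2C)n(C)c1=O`: 34000 nM
compound 3, `Cn1c(=O)c2c(nc(CCSc3cccc(Cl)c3)n2C)n(C)c1=O`: "not active" (no number reported)

The read-out throughout is an in vitro assay on cells for inhibition of Amine oxidase [flavin-containing] A (Homo sapiens), read by coupled enzyme assay, with a stated time of 20 min; a higher number here means a weaker inhibitor, a lower number a stronger inhibitor. Compound 2 gives the lowest of the two numbers in this assay, at 34000 nM; compound 1, with 372000 nM, lies beyond the scatter above it. Compound 3 is reported inactive without a number, so it cannot be placed on the same scale. None of these pairs differ in a single place, so no single step can be read from the measured set.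

The next compound, compound 4, `Cn1c(=O)c2c(nc(COc3ccc(Br)cc3)n2C)n(C)c1=O`, is not yet measured. Relative to compound 2 the change is 4-bromophenyl in place of 3-bromophenyl on an oxygen on a saturated carbon. Going by the values given here, no comparable step exists among the measured compounds, so there is no measured basis for a direction. The expectation is a step of modest size in either direction, most likely within the scatter: from compound 2 to compound 4 a change of a 1.2-fold higher number from compound 2 to compound 4 (0.07 log units; within the scatter) is estimated. For compound 4 the estimate in this assay is 40000 nM, with a range from 10000 nM to 160000 nM.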

Compound 4, half-maximal inhibitory concentration: 10700 nM
Compound 4: the middle estimate sits 3.7-fold (0.57 log units) above what was measured, and the stated range covers the measured number.
By their numbers in this assay, from the lowest: compound 4; then compound 2; then compound 1.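

In this assay, 4-bromophenyl in place of 3-bromophenyl on an oxygen on a saturated carbon gives a 3.2-fold lower number from compound 2 to compound 4 (0.50 log units; beyond the scatter), the first single-place step available in the series, modest in size but beyond the scatter. The leaving and entering groups have the same heavy-atom count and the same ring, so the read-out responds to where the bromine sits on the phenyl ring and not only to its presence, and at this position the 4-bromophenyl group is the better of the two tested. No measured data bear on why the number falls with this change.

Unsubstituted phenyl, 4-chlorophenyl and 4-methoxyphenyl on the same oxygen are absent from the compounds shown, so the contribution of the bromine itself cannot be separated from that of its placement. As far as these compounds go, whether the same exchange gives a step of similar direction and size on the sulfur-containing chain of compound 1, or on a longer chain between the core and the oxygen, also remains open.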